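A few compounds are considered here, and "the series" means these few. Any claim that something is new, unique, unknown or untested is made for them only; others in the source may bear on it.

Measured compounds:

Compound 1 `O=S(=O)(NCCNC(=S)Nc1ccc(Cl)cc1)c1ccc(-c2ccccc2OCc2ccccc2)s1`; in a functional assay on HL-60 cells (Homo sapiens) for inhibition, read by CCK-8 assay, with a stated time of 48 h (on this read-out higher numbers stand for weaker inhibition and lower numbers for stronger inhibition), compound 1 gives > 50000 nM, which is a limit of the assay rather than a number.
Compound 2 `COc1ccc(NC(=O)NCCNS(=O)(=O)c2ccc(-c3ccccc3OCc3cccc(O)c3)s2)cc1`; in this assay compound 2 gives > 20000 nM, again only a limit.
Compound 3 `O=S(=O)(NCCNC(=S)Nc1cc(C(F)(F)F)cc(C(F)(F)F)c1)c1sccc1-c1ccccc1Oc1ccc(O)c(O)c1`; in this assay compound 3 gives 4300 nM.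

Among these three, compound 1 stands at the weak end: its result is the limit (the limit of > 50000 nM in this assay, at which 1 of the 3 values shown sits), and compound 2 sits at the other limit, (the limit of > 20000 nM in this assay, at which 1 of the 3 values shown sits), so neither of these two gave a measurable number, while compound 3 is the only one with a value.

Compound 4 `O=C(NCCNS(=O)(=O)c1ccc(-c2ccccc2OCc2ccccc2)s1)Nc1cccc([N+](=O)[O-])c1` keeps the shared core of compound 1 and changes one place: a group of 12 heavy atoms (7 carbon, 2 nitrogen, 3 oxygen; one six-membered aromatic ring of carbon only) in place of a group of 10 heavy atoms (7 carbon, 1 nitrogen, 1 sulfur, 1 chlorine; one six-membered aromatic ring of carbon only), on an amine nitrogen. The (3-nitrophenyl)carbamoyl group, with its three oxygen atoms and three hydrogen-bond acceptors, replaces the smaller chlorine- and sulfur-bearing group on the amine nitrogen next to the saturated chain carbon.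

Within the data shown here, no measured pair in this set differs in only one place, so there is no measured step to lean on. Compound 2, which also carries a carbamoyl-type group on the same kind of nitrogen, stays at a limit, and compound 1 stays at a limit; the expectation for compound 4 is therefore that it remains weak, with no change beyond the scatter, a step of an at least 1.2-fold lower number from compound 1 to compound 4 (0.09 log units; that floor lies within the scatter). Compound 4 is estimated at 40000 nM, with a likely range from 8000 nM to 150000 nM.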

Compound 4, half-maximal inhibitory concentration: 2800 nM
The estimate for compound 4 lay 14-fold (1.15 log units) above the measured number, and the stated range ends above it.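

In this assay, replacing the group that holds sulfur and chlorine with (3-nitrophenyl)carbamoyl on the amine nitrogen gives an at least 17-fold lower number from compound 1 to compound 4 (1.25 log units; beyond the scatter). Among these compounds, this is the first measured step at this place, and it shows that the group on this nitrogen can by itself take the shared core of compound 1 from a limit of the assay to a measured number, since nothing else in the structure differs. The true size of the step may be larger than printed, because compound 1 gives only a limit and not a number: the limit of > 50000 nM in this assay, at which 1 of the 4 values shown sits.

The exchange alters several things at once, removing the sulfur and the chlorine and bringing in the carbonyl and the nitro group, so the compounds shown cannot say which of these changes carries the step. Going by these compounds, it also stays open whether the step would survive with an amine or a carboxylic acid in place of the nitro group, or whether the same exchange would give a similar step on a different core.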